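The source may report more compounds than this note shows. Statements on the series, on what has been measured and on what is new or still open speak of the compounds shown alone.

- Compound 1 `CCOC(=O)c1csc2nc(CN3CCN(Cc4ccccc4)CC3)c(-c3ccc(C)cc3)n12`: 38800 nM
- Compound 2 `CCOC(=O)c1csc2nc(CN3CCN(C)CC3)c(-c3ccc(OC)cc3)n12`: 35100 nM

In a functional assay on HeLa cells (Homo sapiens) for antiproliferative activity, read by MTT assay, with a stated time of 72 h (on this read-out higher numbers stand for weaker inhibition and lower numbers for stronger inhibition), compound 2 gives 35100 nM and compound 1 gives 38800 nM, so these two stand within the usual scatter of each other. Compound 3 `CCOC(=O)c1csc2nc(CN3CCN(Cc4ccccc4)CC3)c(-c3ccc(OC)cc3)n12` keeps everything in compound 2 except one place: phenyl in place of hydrogen on a saturated chain carbon bound to an amine nitrogen in a ring. Put simply, methyl becomes benzyl. Among the compounds with values here, no measured pair shows this change alone. Compound 1 also carries benzyl and gives 38800 nM, so no shift beyond the scatter is expected in this assay. The expected size is a 1.1-fold lower number from compound 2 to compound 3 (0.03 log units; within the scatter). Compound 3 is expected at 33000 nM, with an estimated range of 14000 nM to 75000 nM.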

Compound 3, half-maximal inhibitory concentration: 9940 nM
Compound 3: the middle estimate sits 3.3-fold (0.52 log units) above what was measured, outside the stated range (below it).
By their numbers in this assay, from the lowest: compound 3; then compounds 2 and 1 (each within the scatter of the next).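

In this assay, methyl to benzyl now shows a real step when methoxy is present (a 3.5-fold lower number from compound 2 to compound 3 (0.55 log units; beyond the scatter)), and methoxy in place of methyl on an aromatic carbon shows one when benzyl is present (a 3.9-fold lower number from compound 1 to compound 3 (0.59 log units; beyond the scatter)). The close values of compound 1 and compound 2 had given no sign of this, since those two differ in two places and only compound 3 carries both benzyl and methoxy. Nothing here explains either step. As far as these compounds go, whether a longer chain such as phenylethyl or a benzyl bearing a chlorine would follow compound 3 stays open, as does what benzyl does with methyl on the aromatic carbon.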